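The source may report more compounds than this note shows. Statements on the series, on what has been measured and on what is new or still open speak of the compounds shown alone.

Measured so far in a functional assay on MDA-MB-436 cells (Homo sapiens) for antiproliferative activity, read by MTT assay, with a stated time of 48 h; on this read-out lower numbers stand for stronger inhibition and higher numbers for weaker inhibition:
- compound 1 `C=CS(=O)(=O)N1CCN(c2ncnc3sc(-c4ccccc4)cc23)CC1`: 21100 nM
- compound 2 `C=CS(=O)(=O)N1CCN(c2ncnc3sc(-c4cn(S(=O)(=O)c5ccccc5)c5ccccc45)cc23)CC1`: 38000 nM
- compound 3 `C=CS(=O)(=O)N1CCN(c2ncnc3sc(-c4ccc(OC)nc4)cc23)CC1`: 11900 nM

In this assay, compound 3 at 11900 nM cannot be told apart from compound 1 at 21100 nM, while compound 2 shows the higher number of 38000 nM.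

Compound 4 `C=CS(=O)(=O)N1CCN(c2ncnc3sc(C4=CCCCC4)cc23)CC1` keeps the shared core and swaps one group: cyclohex-1-en-1-yl in place of 6-methoxypyridin-3-yl, on the aromatic carbon next to the ring sulfur (cyclohex-1-en-1-yl in place of 6-methoxypyridin-3-yl on an aromatic carbon).

Within the data shown here, only one measured step bears directly on this swap. Replacing phenyl with 6-methoxypyridin-3-yl at this carbon gave a 1.8-fold lower number from compound 1 to compound 3 (0.25 log units; within the scatter), so that exchange of one six-membered ring for another moved the number by no more than ordinary repeat variation. Among the measured compounds shown here, none of the measured compounds carries a non-aromatic ring here, so this guide is indirect. No step beyond the scatter is therefore expected, with a slight lean towards the higher number of compound 1.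

The expected change is a 1.3-fold higher number from compound 3 to compound 4 (0.10 log units; within the scatter).

For compound 4 the estimated value is 15000 nM, with an expected range from 7500 nM to 30000 nM.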

Compound 4, half-maximal inhibitory concentration: > 50000 nM
Compound 4 gave a limit, no number; the forecaster's own chance of this, stated with the estimate: 5%; at least 3.3-fold (0.52 log units) between middle value and limit.
By their numbers in this assay, from the lowest: compounds 3, 1 and 2 (each within the scatter of the next, the first and the last beyond it). At a limit, above all of these: compound 4.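

Compound 4 gave only a limit, not a number, in this assay: the limit of > 50000 nM in this assay, at which 1 of the 4 values shown sits.

Among these compounds, this position is less tolerant than the earlier compounds suggested. Exchanging one aromatic ring for another gave a 1.8-fold lower number from compound 1 to compound 3 (0.25 log units; within the scatter), whereas the non-aromatic cyclohex-1-en-1-yl gave an at least 4.2-fold higher number from compound 3 to compound 4 (0.62 log units; beyond the scatter) and an at least 2.3-fold higher number from compound 1 to compound 4 (0.37 log units; beyond the scatter). Among these four compounds, only the one without an aromatic ring on the aromatic carbon next to the ring sulfur failed to give a number, and this rests on compound 4 alone.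

From the compounds shown here alone, how far the true value of compound 4 lies beyond its limit remains unknown. Going by these compounds, it is also open whether a piperidine ring, a morpholine ring or an open butyl chain at this carbon would behave like cyclohex-1-en-1-yl.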